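Trifluoromethoxy in Place of Methyl on Compound 1

A few compounds are considered here, and "the series" means these few. Any claim that something is new, unique, unknown or untested is made for them only; others in the source may bear on it.

Compound 1 `Cc1ccc(-n2nc(-c3ccc(C(F)(F)F)cc3O)nc2-c2ccccc2O)cc1` was tested in a functional assay on PC-12 cells (Rattus norvegicus) for cytotoxicity, read by MTT assay, with stated times of 2 h and 24 h, tested at 5 uM (on this read-out lower numbers stand for a weaker effect and higher numbers for a stronger effect at the one concentration tested), where compound 1 gives 94.1%. Going by the values given here, its only measured neighbour is compound 2 `CCc1ccc(-n2nc(-c3ccc(C(F)(F)F)cc3O)nc2-c2ccccc2O)cc1`, which in this assay gives 95.4%. The step from one to the other, methyl in place of hydrogen on a saturated chain carbon bound to an aromatic carbon, reads a number 1.3 percentage points higher from compound 1 to compound 2 (within the scatter). Among the compounds with values here, of the two numbers so far, compound 1 stands lowest, but compound 2 lies within the scatter of it, so the two cannot be ordered.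

Compound 3 `Oc1cc(C(F)(F)F)ccc1-c1nc(-c2ccccc2O)n(-c2ccc(OC(F)(F)F)cc2)n1` has not yet been measured. It differs from compound 1 by trifluoromethoxy in place of methyl on an aromatic carbon. Within the data shown here, the one measured step, a number 1.3 percentage points higher from compound 1 to compound 2 (within the scatter), touches the same substituent and did not move the read-out beyond the scatter, and both measured compounds already sit close to the top of the scale. The expectation for the step to compound 3 in this assay is therefore no change beyond the scatter, with a small allowance downward because compound 1 already gives 94.1%, close to the top of the scale. For compound 3 the estimate is 92%, between 80% and 100%, meaning an expected step of a number 2.1 percentage points lower from compound 1 to compound 3 (within the scatter).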

Compound 3, a percentage reported as activity, at one concentration (the size of the read-out at that concentration, not a potency): 84.9%
Compound 3: middle estimate off by 7.1 percentage points, on the high side; measured number inside the range.
By their numbers in this assay, from the lowest: compounds 3, 1 and 2 (each within the scatter of the next, the first and the last beyond it).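

At this position, on an aromatic carbon para to a large group, this assay now gives its first step beyond the scatter, though a modest one: trifluoromethoxy in place of ethyl reads a number 10.5 percentage points lower from compound 2 to compound 3 (beyond the scatter). Trifluoromethoxy in place of methyl reads a number 9.2 percentage points lower from compound 1 to compound 3 (within the scatter), so compound 3 cannot be ordered against compound 1, and compound 1 cannot be ordered against compound 2 either; the only separation among the three lies between the two ends of the series, which the earlier pair alone could not show. Nothing at hand bears on why the read-out differs between these groups.

The compounds shown leave open how a methoxy group, a chlorine atom or an amine would read at this position, and so whether the separation is particular to trifluoromethoxy or would also appear with other groups in its place. They also leave open how any of the three compounds would read at concentrations other than the one tested, where a separation now seen only between compound 2 and compound 3 might widen or disappear.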